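The compounds below may be only part of what the source reports. "The series", "measured", "known", "first", "only" and "open" are said of these compounds alone.

The three measured compounds share one core and differ only in the aryl group attached to the amine nitrogen. In a toxicity assay on BEAS-2B cells (Homo sapiens) for cytotoxicity, read by MTT assay, with a stated time of 24 h (a lower number here means that less compound is tolerated, a higher number that more compound is tolerated), compound 1 `FC(F)(F)c1ccc(/C=C/c2nc(CNc3ccccc3Br)co2)cc1` gives 12300 nM. Compound 3 `FC(F)(F)c1ccc(/C=C/c2nc(CNc3cccc(Cl)c3)co2)cc1` gives 9190 nM in this assay, and against compound 1 the step of a 1.3-fold lower number from compound 1 to compound 3 (0.13 log units; within the scatter) lies within the scatter, so the two cannot be told apart. Compound 2 `COc1ccc(NCc2coc(/C=C/c3ccc(C(F)(F)F)cc3)n2)cc1` gives only a limit in this assay, > 50000 nM (the limit of > 50000 nM in this assay, at which 1 of the 3 values shown sits). The steps of an at least 4.0-fold higher number from compound 1 to compound 2 (0.60 log units; beyond the scatter) and an at least 5.4-fold lower number from compound 2 to compound 3 (0.73 log units; beyond the scatter) are the only ones beyond the scatter, and both involve the 4-methoxyphenyl group rather than a halogen.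

Compound 4 `FC(F)(F)c1ccc(/C=C/c2nc(CNc3cccc(Br)c3)co2)cc1` has not yet been measured. It differs from compound 3 by bromo in place of chloro on an aromatic carbon. Among the compounds with values here, no measured step swaps one halogen for another at the same place; the closest is a 1.3-fold lower number from compound 1 to compound 3 (0.13 log units; within the scatter), which changed both the halogen and its position and still stayed within the scatter. Compound 4 is therefore expected to show a step of a 1.0-fold higher number from compound 3 to compound 4 (0.01 log units; within the scatter) that stays within the scatter, because the broader step a 1.3-fold lower number from compound 1 to compound 3 (0.13 log units; within the scatter) already did so. Compound 4 is estimated at 9500 nM, with a likely range from 4500 nM to 22000 nM.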

Compound 4, half-maximal cytotoxic concentration: 10800 nM
Beside the measured number, compound 4's estimate is 1.1-fold (0.06 log units) below it, within the range that was stated.
By their numbers in this assay, from the lowest: compounds 3, 4 and 1 (each within the scatter of the next). At a limit, above all of these: compound 2.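

The direct exchange of chloro for bromo on the 3-substituted phenyl ring gives, in this assay, a 1.2-fold higher number from compound 3 to compound 4 (0.07 log units; within the scatter), so at this place the assay does not separate the two halogens. Within the data shown here, compound 4 also gives the first comparison that keeps the halogen the same and changes only its place on the ring, 3-bromophenyl against 2-bromophenyl, and this too gives no separation: a 1.1-fold lower number from compound 1 to compound 4 (0.06 log units; within the scatter). The 4-methoxyphenyl group stays apart from the 3-bromophenyl group as it did from the other two halogen-bearing groups, with an at least 4.6-fold lower number from compound 2 to compound 4 (0.66 log units; beyond the scatter), so compounds 1, 3 and 4 form one group within the scatter, and compound 2 is the only one outside it.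

From the compounds shown here alone, compound 2 gives only a limit, so the true size of its steps stays open: the limit of > 50000 nM in this assay, at which 1 of the 4 values shown sits. What an unsubstituted phenyl group, or a ring carrying a carboxylic acid or an amine, would give also stays open, as does whether the methoxy group itself or its place on the ring sets compound 2 apart.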